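A few compounds are considered here, and "the series" means these few. Any claim that something is new, unique, unknown or untested is made for them only; others in the source may bear on it.

Measured compounds:
compound 1, `O=C(CN1CCN(c2nnc(Cc3ccncc3)c3ccccc23)CC1)Nc1cccc(Br)c1`, gives 1.7 nM in a functional assay on MDA-MB-231 cells (Homo sapiens) for cytotoxicity, read by MTT assay, with a stated time of 72 h; a higher number here means a weaker inhibitor, a lower number a stronger inhibitor.
compound 2, `O=C(CN1CCN(c2nnc(Cc3ccncc3)c3ccccc23)CC1)Nc1ccc(F)c(Cl)c1`, gives 4 nM in this assay.
compound 3, `O=C(CN1CCN(c2nnc(Cc3ccccc3)c3ccccc23)CC1)Nc1ccc(F)c(Cl)c1`, gives 7360 nM in this assay.

Compound 4, `O=C(CN1CCN(c2nnc(Cc3ccccc3)c3ccccc23)CC1)Nc1cccc(Br)c1`, has not yet been measured in this assay. It is related to compound 3 by the change (3-bromophenyl in place of 3-chloro-4-fluorophenyl on an amide-type nitrogen). The same change has already been measured once, from compound 2 to compound 1, as 3-bromophenyl in place of 3-chloro-4-fluorophenyl on an amide-type nitrogen, and there it made a step of a 2.4-fold lower number from compound 2 to compound 1 (0.37 log units; beyond the scatter). The two places are described in the same words, so this is the same change made on a different core. The cores of compound 3 and compound 2 differ by phenyl in place of pyridin-4-yl on a saturated chain carbon bound to an aromatic carbon, and that difference carried a step of a 1800-fold higher number from compound 2 to compound 3 (3.26 log units; beyond the scatter), which is where compound 3 stands apart from the other two measured compounds.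

Compound 4 thus combines the core of compound 3 with the amide substituent of compound 1. Among the measured compounds shown here, one expects compound 4 to remain near compound 3 in this assay, with a step of about a 2.1-fold lower number from compound 3 to compound 4 (0.32 log units; beyond the scatter), because the only precedent for this change, a 2.4-fold lower number from compound 2 to compound 1 (0.37 log units; beyond the scatter), was modest, and nothing measured suggests the core of compound 3 responds to it differently. Whether the step transfers unchanged between the two cores rests on a single measured pair, so the range is kept wide. The estimate for compound 4 in this assay is 3500 nM, between 1000 nM and 12000 nM.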

Compound 4, half-maximal inhibitory concentration: 3880 nM
Estimate against measurement, compound 4: 1.1-fold (0.04 log units) below; the range from low to high includes it.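

In this assay, 3-bromophenyl in place of 3-chloro-4-fluorophenyl on the amide-type nitrogen gave a 1.9-fold lower number from compound 3 to compound 4 (0.28 log units; within the scatter), and this step agrees with the one seen on the core that carries pyridin-4-yl: the same change on two cores in this assay, a 2.4-fold lower number (0.37 log units; beyond the scatter) from compound 2 to compound 1 and a 1.9-fold lower number (0.28 log units; within the scatter) from compound 3 to compound 4, 1.2-fold (0.09 log units) apart, within the scatter of two such steps. The other edge of the set of four compounds behaves the same way, with phenyl in place of pyridin-4-yl giving a 2300-fold higher number from compound 1 to compound 4 (3.36 log units; beyond the scatter) in the 3-bromophenyl amides, a step that matches the one seen in the 3-chloro-4-fluorophenyl amides: the same change on two cores in this assay, a 1800-fold higher number (3.26 log units; beyond the scatter) from compound 2 to compound 3 and a 2300-fold higher number (3.36 log units; beyond the scatter) from compound 1 to compound 4, 1.2-fold (0.09 log units) apart, within the scatter of two such steps. Within these four compounds the two changes therefore add up without any sign that one alters the size of the other, and the exchange on the chain carbon accounts for far more of the spread than the exchange on the amide; this rests on only two cores and two amide substituents, however, and it does not show that the amide change would carry over to any other core or explain why either step has its size.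

The compounds shown leave open whether a pyridin-3-yl or pyridin-2-yl group on the chain carbon would keep the level of the pyridin-4-yl compounds or fall to that of the phenyl compounds. They also leave open whether an amide substituent outside the halogenated phenyl groups, such as 3-methoxyphenyl or cyclohexyl, would follow the same additive pattern on both cores.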